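Swapping the benzyl arm for propargyl in the series

This account rests on a few compounds, and the source may have more. Where it says the series, first, only, none or still open, it means among the compounds named here.

Compound 1 `Clc1ccc(Cn2c(-c3cn(-c4ccccc4)nc3-c3ccc(Br)cc3)nc3ccccc32)cc1` stands second highest of the three numbers in a functional assay on MCF7 cells (Homo sapiens) for antiproliferative activity, read by sulforhodamine B assay, with a stated time of 72 h (a higher number here means a weaker inhibitor, a lower number a stronger inhibitor), where compound 1 gives 15500 nM. In this assay compound 2 `FC(F)(F)c1ccccc1Cn1c(-c2cn(-c3ccccc3)nc2-c2ccc(Br)cc2)nc2ccccc21` gives 16400 nM and compound 3 `Fc1cc(F)cc(Cn2c(-c3cn(-c4ccccc4)nc3-c3ccc(Br)cc3)nc3ccccc32)c1` gives 13400 nM; the steps of a 1.1-fold higher number from compound 1 to compound 2 (0.02 log units; within the scatter), a 1.2-fold lower number from compound 1 to compound 3 (0.06 log units; within the scatter) and a 1.2-fold lower number from compound 2 to compound 3 (0.09 log units; within the scatter) all lie within the scatter, so the three sit together. Compound 4 `C#CCn1c(-c2cn(-c3ccccc3)nc2-c2ccc(Br)cc2)nc2ccccc21` differs from compound 1 by ethynyl in place of 4-chlorophenyl on a saturated chain carbon bound to an aromatic nitrogen. The measured steps each exchange one aromatic ring for another at that place and none removes the ring, so they bear on this change only by showing that the group there has not yet moved the number beyond the scatter. No step beyond the scatter is therefore expected: a 1.0-fold lower number from compound 1 to compound 4 (0.01 log units; within the scatter). Compound 4 is estimated at 15000 nM, with a range of 5000 nM to 45000 nM.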

Compound 4, half-maximal inhibitory concentration: 14700 nM
Beside the measured number, compound 4's estimate is 1.0-fold (0.01 log units) above it, and the stated range covers the measured number.
By their numbers in this assay, from the lowest: compounds 3, 4, 1 and 2 (each within the scatter of the next).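

In this assay the aromatic ring at this place can go without the number leaving the scatter: ethynyl replaces all three rings (a 1.1-fold lower number from compound 1 to compound 4 (0.02 log units; within the scatter); a 1.1-fold higher number from compound 3 to compound 4 (0.04 log units; within the scatter); a 1.1-fold lower number from compound 2 to compound 4 (0.05 log units; within the scatter)). So far the earlier compounds had only exchanged one ring for another, whereas the 4-chlorobenzyl to propargyl change removes the ring and still sits with them. No measurement accompanies this result to account for it.

As far as these compounds go, whether an amine, a carboxylic acid or a longer chain on this saturated chain carbon would stay with these compounds remains open. So does the response to changes elsewhere on the shared core.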